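Swapping a chloro for a methyl on the anilide ring

This account rests on a few compounds, and the source may have more. Where it says the series, first, only, none or still open, it means among the compounds named here.

Measured so far:
- compound 1 `CCN(CC)CCCOc1cc2ncnc(Nc3nc4ccc(C(=O)Nc5c(C)cccc5C)cc4s3)c2cc1OC`: > 100000 nM
- compound 2 `COc1cc2c(Nc3nc4ccc(C(=O)Nc5c(C)cc(C)cc5C)cc4s3)ncnc2cc1OCCCN1CCCCC1C`: 5700 nM
- compound 3 `CCN(CC)CCCOc1cc2ncnc(Nc3nc4ccc(C(=O)Nc5c(C)cccc5Cl)cc4s3)c2cc1OC`: 11700 nM

In a functional assay on DLD-1 cells (Homo sapiens) for cytotoxicity, read by WST assay, with a stated time of 72 h (a lower number here means a stronger inhibitor, a higher number a weaker inhibitor), compound 1 reaches only a limit, > 100000 nM. Compound 3 has the higher of the two real numbers, with compound 2 the nearest at a lower value. The step of an at least 8.5-fold lower number from compound 1 to compound 3 (0.93 log units; beyond the scatter) is the only measured one, and it runs the opposite way to the change now considered. Compound 4 `CCN(CC)CCCOc1cc2ncnc(Nc3nc4ccc(C(=O)Nc5c(C)cc(C)cc5C)cc4s3)c2cc1OC` differs from compound 3 by 2,4,6-trimethylphenyl in place of 2-chloro-6-methylphenyl on an amide-type nitrogen. Compound 2 also carries a 2,4,6-trimethylphenyl, with a different side chain, and gives 5700 nM. A weakening step is therefore expected, a 1.0-fold higher number from compound 3 to compound 4 (0.01 log units; within the scatter), though the extra methyl on the ring leaves this uncertain. Compound 4 is estimated at 12000 nM, between 3000 nM and 60000 nM.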

Compound 4, half-maximal inhibitory concentration: 6800 nM
For compound 4 the middle estimate is 1.8-fold (0.25 log units) above the measured one; the range from low to high includes it.
By their numbers in this assay, from the lowest: compounds 2, 4 and 3 (each within the scatter of the next, the first and the last beyond it). At a limit, above all of these: compound 1.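

On the amide-type nitrogen, 2,4,6-trimethylphenyl and 2-chloro-6-methylphenyl cannot be told apart in this assay (a 1.7-fold lower number from compound 3 to compound 4 (0.24 log units; within the scatter)). Diethylamino and 2-methylpiperidin-1-yl on the saturated chain also cannot be told apart (a 1.2-fold higher number from compound 2 to compound 4 (0.08 log units; within the scatter)). Methyl in place of hydrogen on an aromatic carbon gives the only large step among these (an at least 14-fold lower number from compound 1 to compound 4 (1.16 log units; beyond the scatter)), and its size is only a bound, as compound 1 stands at a limit: the limit of > 100000 nM in this assay, at which 1 of the 4 values shown sits.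

Still open, going by these compounds, is how an amine or a carboxylic acid on that phenyl ring would behave. A longer chain in place of the methyl groups is equally untested here.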